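The compounds below may be only part of what the source reports. "The series", "measured", "known", "first", "only" and "open" are said of these compounds alone.

Among the compounds with values here, in a functional assay on HT-29 cells (Homo sapiens) for inhibition (a lower number here means a stronger inhibitor, a higher number a weaker inhibitor), compound 1 (`COc1ccc(/C=C\c2ccc3ccccc3c2)cc1[N+](=O)[O-]`) gives 3280 nM and compound 2 (`COc1cc(/C=C\c2ccc3ccccc3c2)cc([N+](=O)[O-])c1OC`) gives 420 nM as the lower of the only two numbers so far. Next is compound 3 (`COc1cc(/C=C\c2ccc3ccccc3c2)cc(N)c1OC`), which carries amino in place of nitro on an aromatic carbon, ortho to a methoxy group (amino in place of nitro on an aromatic carbon). Within the data shown here, the only measured step is a 7.8-fold lower number from compound 1 to compound 2 (0.89 log units; beyond the scatter) for methoxy in place of hydrogen on an aromatic carbon. That step is modest and leaves the nitro untouched, so it serves only as a rough guide to size. A modest step is therefore expected in this assay with its direction unsettled by the data and a slight lean to a lower number. The step estimated for compound 3 is a 1.7-fold lower number from compound 2 to compound 3 (0.23 log units; within the scatter) and remains tentative. For compound 3 the estimated value is 250 nM (expected range 50 nM to 1300 nM).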

Compound 3, half-maximal inhibitory concentration: 330 nM
Compound 3: the middle estimate sits 1.3-fold (0.12 log units) below what was measured; the range from low to high includes it.
By their numbers in this assay, from the lowest: compounds 3 and 2 (each within the scatter of the next); then compound 1.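

In this assay, amino in place of nitro on an aromatic carbon, ortho to a methoxy group, gives a 1.3-fold lower number from compound 2 to compound 3 (0.10 log units; within the scatter) and so leaves the two groups indistinguishable in this read-out. Compound 1 and compound 2 both carry the nitro, so only now does the series show that, on the core of compound 2, nitro is not needed for a value of this size. The match holds even though amino has one heavy atom against three for nitro and brings a hydrogen-bond donor that nitro lacks. Nothing measured here bears on why the two groups read alike.

Still open, going by these compounds, is whether an acetamide, a hydroxyl or a fluorine at this position would also fit. On these data alone, it is also open whether amino gives the same result without the added methoxy group, on the core of compound 1.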